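The source may hold more compounds than are shown below. What is called first, only, known or untested is meant among the compounds shown, and "the series" means these compounds.

Three close relatives built on one shared core have been tested in an ADME assay on MT4 cells (Homo sapiens) for cytotoxicity, read by MTT assay, with a stated time of 5 days; on this read-out lower numbers stand for higher toxicity in this test and higher numbers for lower toxicity in this test. Compound 1 `Cc1cc(C#N)cc(C)c1Oc1nc(NC2CCC(NC(=O)c3ccccc3)CC2)nc2ccsc12` gives 3930 nM, compound 2 `Cc1cc(C#N)cc(C)c1Oc1nc(NC2CCC(NS(=O)(=O)c3cccc(C(F)(F)F)c3)CC2)nc2ccsc12` gives 6680 nM, and compound 3 `Cc1cc(C#N)cc(C)c1Oc1nc(NC2CCC(NS(=O)(=O)c3ccc(C#N)cc3)CC2)nc2ccsc12` gives 9290 nM, the highest number of the three, although its gap to compound 2 lies within the scatter. The step of a 2.4-fold higher number from compound 1 to compound 3 (0.37 log units; beyond the scatter) is the only one beyond the scatter, while the step of a 1.4-fold higher number from compound 2 to compound 3 (0.14 log units; within the scatter) is not. Compound 4 `Cc1cc(C#N)cc(C)c1Oc1nc(NC2CCC(NC(=O)c3ccc(F)cc3)CC2)nc2ccsc12` differs from compound 3 by (4-fluorophenyl)carbonyl in place of (4-cyanophenyl)sulfonyl on an amine nitrogen, which largely reverses the change seen between compound 1 and compound 3. For compound 4 the step of a 2.1-fold lower number from compound 3 to compound 4 (0.31 log units; beyond the scatter) is therefore expected, a downward move of modest size. Compound 4 is estimated at 4500 nM, with a likely range from 2000 nM to 10000 nM.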

Compound 4, half-maximal cytotoxic concentration: 3180 nM
Compound 4: the middle estimate sits 1.4-fold (0.15 log units) above what was measured; measured number inside the range.
By their numbers in this assay, from the lowest: compounds 4, 1, 2 and 3 (each within the scatter of the next, the first and the last beyond it).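

Swapping the (4-cyanophenyl)sulfonyl group on this amine nitrogen for (4-fluorophenyl)carbonyl gives a 2.9-fold lower number from compound 3 to compound 4 (0.47 log units; beyond the scatter), so this carbonyl compound also sits clearly below the sulfonyl compound 3. Fluoro in place of hydrogen on the benzoyl ring gives only a 1.2-fold lower number from compound 1 to compound 4 (0.09 log units; within the scatter), a step within the scatter in this assay. Nothing available explains either step. Going by these compounds, the step from compound 3 to compound 4 changes both the linking group and the ring substituent at once, so it remains open which change matters. A 4-cyanobenzoyl group on the same nitrogen would separate the two.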